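Nitro in Place of Methylsulfonyl on a Biaryl Amide Acid

The source may report more compounds than this note shows. Statements on the series, on what has been measured and on what is new or still open speak of the compounds shown alone.

Compound 3 `CC(C)N(Cc1cccc(OCCCCCC(=O)O)c1)C(=O)c1ccc(-c2cccc(S(C)(=O)=O)c2)cc1` carries a methylsulfonyl group on the outer ring of its biaryl amide. In an ADME assay on BJ cells (Homo sapiens) for cytotoxicity, read by CellTiter-Glo and resazurin assay, with a stated time of 72 h (on this read-out lower numbers stand for an effect already at smaller amounts and higher numbers for an effect only at larger amounts of compound), compound 3 gives > 26000 nM, which is a limit of the assay and not a number. Compound 1 `CC(C)N(Cc1cccc(OCCCCCC(=O)O)c1)C(=O)c1ccc(-c2cccc(OCc3ccccc3)c2)cc1`, the benzyloxy analogue, gives in this assay > 26000 nM, likewise a limit. Compound 2 `COc1ccc(F)c(-c2ccc(C(=O)N(Cc3cccc(OCCCCCC(=O)O)c3)C(C)C)cc2)c1`, bearing a 2-fluoro-5-methoxyphenyl group, gives in this assay > 26000 nM, again a limit. Accordingly a step that the two limits leave unreadable from compound 1 to compound 3 and a step that the two limits leave unreadable from compound 2 to compound 3; neither can be sized because of the limit of > 26000 nM in this assay, at which 3 of the 3 values shown sit.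

Compound 4 `CC(C)N(Cc1cccc(OCCCCCC(=O)O)c1)C(=O)c1ccc(-c2cccc([N+](=O)[O-])c2)cc1` has not yet been measured. It differs from compound 3 in one place: nitro in place of methylsulfonyl on an aromatic carbon. The two steps that bear on this change, both leading to the methylsulfonyl compound, end at the same limit as their starting points, so they give no direction for the new group. Since every measured value in this series sits at the limit, the expectation for compound 4 in this assay is that it too will be reported as a limit rather than a number. Compound 4 is therefore expected to show a step that the limit leaves unreadable from compound 3 to compound 4. Compound 4 is estimated at 30000 nM, with a range from 15000 nM to 100000 nM.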

Compound 4, half-maximal effective concentration: > 26000 nM
Compound 4 was reported as a limit; the forecaster's own chance of this, stated with the estimate: 85%; the middle value lies beyond the limit too.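

In this assay compound 4 gives > 26000 nM, a limit of the assay and not a number. No step from compound 1, compound 2 or compound 3 to compound 4 can be read because all the values share one limit: the limit of > 26000 nM in this assay, at which 4 of the 4 values shown sit.

The compounds shown leave open how nitro and methylsulfonyl compare, and whether any of these compounds would give a number in this assay.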